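The source may report more compounds than this note shows. Statements on the series, on what has been measured and on what is new or still open speak of the compounds shown alone.

Measured so far in an assay on HeLa cells for inhibition of sphingosine-1-phosphate transporter SPNS2 (Mus musculus), read by LC-MS, tested at 2 uM; a higher number here means more inhibition at the concentration tested (going by the name of the read-out), a lower number less inhibition:
- compound 1 `CCCCCCCCCCc1ccc(-c2noc(CN)n2)cc1`: compound 1 gives 62%
- compound 2 `CCCCCCCCCCc1ccc(-c2noc(CC3CNC3)n2)cc1`: compound 2 gives 63%
- compound 3 `CCCCCCCCCCc1ccc(-c2noc([C@@H]3CCNC3)n2)cc1`: compound 3 gives 62%

Compound 3 stands level with compound 1 at the digits shown, and the two together are the lowest of the three numbers; the nearest neighbour of compound 3 is compound 1, with no change at the digits printed from compound 1 to compound 3 (within the scatter), and the furthest is compound 2, with a number 1 percentage points lower from compound 2 to compound 3 (within the scatter). Every step in the set, also a number 1 percentage points higher from compound 1 to compound 2 (within the scatter), lies within the scatter, so exchanging the amine-bearing part has so far left the read-out in this assay essentially unchanged.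

Compound 4 `CCCCCCCCCCc1ccc(-c2noc(C3CCNC3)n2)cc1` is next to be measured in this assay. Its difference from compound 3: the two compounds have the same atoms and bonds; at least one stereo element is drawn with a configuration in one of them and without one in the other: 1 of 1 stereo elements differ; a stereocentre at a saturated ring carbon is drawn R in compound 3 and without a configuration in compound 4. For the measured compounds named here, no measured step addresses a change of drawn configuration alone, so the three steps bear on it only indirectly: each shows that variation around the amine leaves the number within the scatter. Material without a drawn configuration may contain the other configuration at that ring carbon as well, which no measured pair tests; the number is therefore expected to sit at or somewhat under that of compound 3, with a number 4 percentage points lower from compound 3 to compound 4 (within the scatter) as the expected step, inside the scatter. The estimate for compound 4 in this assay is 58%, with a range from 46% to 68%.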

Compound 4, a percentage reported as inhibition, at one concentration (the size of the read-out at that concentration, not a potency): 26%
The estimate for compound 4 lay 32 percentage points above the measured number, and the stated range ends above it.
By their numbers in this assay, from the lowest: compound 4; then compounds 1, 3 and 2 (each within the scatter of the next).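

In this assay, the pyrrolidin-3-yl series is not as insensitive as the earlier amine exchanges suggested: removing the drawn R configuration at the saturated ring carbon, with atoms and bonds unchanged, gives a large loss (a number 36 percentage points lower from compound 3 to compound 4 (beyond the scatter)). The earlier steps among compounds 1, 2 and 3 all lay within the scatter, so this is the first change in the set shown to move the read-out beyond it, and the level numbers seen around the amine do not extend to compound 4, which also falls well under the two other amines (a number 37 percentage points lower from compound 2 to compound 4 (beyond the scatter); a number 36 percentage points lower from compound 1 to compound 4 (beyond the scatter)). At this position the drawn stereochemistry therefore matters more than the amine exchanges did, and the only structural difference available to account for the gap between compounds 3 and 4 is this one: the fact that one of compounds 3 and 4 is drawn with a defined configuration and the other without, at the place where they differ.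

As far as these compounds go, the stereochemical makeup of compound 4 remains open, as does the number that material drawn with the S configuration at that ring carbon would give. Also open, from the compounds shown here alone, is whether a piperidin-3-yl group, which has its own ring stereocentre, would show the same dependence on drawn configuration.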